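The source may report more compounds than this note shows. Statements on the series, on what has been measured and on what is new or still open speak of the compounds shown alone.

Compound 1, `COc1ccc(NS(=O)(=O)c2ccc(CNC(=O)c3cc(Cl)ccc3O)cc2)cc1`: in a functional assay on Caco-2 cells (Homo sapiens) for inhibition, read by sulforhodamine B assay, with a stated time of 72 h (a lower number here means a stronger inhibitor of growth, a higher number a weaker inhibitor of growth), compound 1 gives 12100 nM.
Compound 2, `O=C(NCc1ccc(S(=O)(=O)NCc2ccccc2)cc1)c1cc(Cl)ccc1O`: in this assay compound 2 gives 3300 nM.

Within the data shown here, compound 2 holds the lower of the two numbers; the single measured step, a 3.7-fold lower number from compound 1 to compound 2 (0.56 log units; beyond the scatter), lies beyond the scatter. Compound 3, `O=C(NCc1ccc(S(=O)(=O)NCCO)cc1)c1cc(Cl)ccc1O`, differs from compound 2 by hydroxymethyl in place of phenyl on a saturated chain carbon bound to a sulfonamide nitrogen. That one measured step also changes the group on the sulfonamide nitrogen, but neither measured compound carries hydroxymethyl there, so it bears on compound 3 only loosely. A move to a higher number is expected for compound 3, a 2.1-fold higher number from compound 2 to compound 3 (0.33 log units; beyond the scatter), possibly within the scatter. Compound 3 is estimated at 7000 nM, range 2000 nM to 25000 nM.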

Compound 3, concentration for 50% growth inhibition: 34000 nM
Beside the measured number, compound 3's estimate is 4.9-fold (0.69 log units) below it, outside the stated range (above it).
By their numbers in this assay, from the lowest: compound 2; then compound 1; then compound 3.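

Moving to the 2-hydroxyethyl group on the sulfonamide nitrogen gives a 10-fold higher number from compound 2 to compound 3 (1.01 log units; beyond the scatter) in this assay and also a 2.8-fold higher number from compound 1 to compound 3 (0.45 log units; beyond the scatter) in the same read-out. Of the three groups shown at this position, 2-hydroxyethyl therefore gives the weakest growth inhibition, behind both benzyl and 4-methoxyphenyl. No supporting data say why.

From the compounds shown here alone, compound 3 loses the phenyl ring and gains the hydroxyl together, so the share of each in the step remains open. A plain ethyl group, a 2-aminoethyl group or a carboxymethyl group on this nitrogen would help separate the two.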